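A few compounds are considered here, and "the series" means these few. Any claim that something is new, unique, unknown or untested is made for them only; others in the source may bear on it.

Measured so far in a functional assay on HeLa cells (Homo sapiens) for antiproliferative activity, read by MTT assay, with a stated time of 24 h; a lower number here means a stronger inhibitor, a higher number a weaker inhibitor:
- compound 1 `COC(=O)c1scc(-c2ccc(NC(=O)c3cccc(C(F)(F)F)c3)cc2)c1OC` gives 19300 nM
- compound 2 `COC(=O)c1scc(-c2ccc(NC(=O)c3cccc(I)c3)cc2)c1OC` gives 12700 nM

Compound 2 lies within the scatter of compound 1, so these two values give no ranking. Compound 3 `COC(=O)c1scc(-c2ccc(NC(=O)c3cccc(OC(F)(F)F)c3)cc2)c1OC` is still unmeasured. The change from compound 2 is trifluoromethoxy in place of iodo on an aromatic carbon with trifluoromethoxy in place of iodo on an aromatic carbon, meta to a large group. Among the measured compounds shown here, only one measured step bears on this: a 1.5-fold lower number from compound 1 to compound 2 (0.18 log units; within the scatter) with iodo in place of trifluoromethyl on an aromatic carbon, and that step stays within the scatter. On that single step, no change beyond the scatter is expected in this assay in either direction. The estimate means a 1.2-fold higher number from compound 2 to compound 3 (0.07 log units; within the scatter) as an expected step, which is inside the scatter. Compound 3 is expected near 15000 nM with an estimated range from 7000 nM to 33000 nM for this read-out.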

Compound 3, half-maximal inhibitory concentration: 16600 nM
The estimate for compound 3 lay 1.1-fold (0.04 log units) below the measured number; the measured number falls inside the stated range.
By their numbers in this assay, from the lowest: compounds 2, 3 and 1 (each within the scatter of the next).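

In this assay, the third group at this position, meta to a large group, again gives no separation: a 1.3-fold higher number from compound 2 to compound 3 (0.12 log units; within the scatter), and a 1.2-fold lower number from compound 1 to compound 3 (0.07 log units; within the scatter). Replacing iodo, 1 heavy atom, with trifluoromethoxy, 5 heavy atoms including 1 hydrogen-bond acceptor, therefore gives no step beyond the scatter, and the three compounds now form one unranked group. No supporting measurement bears on why these values sit together.

The compounds shown leave open whether a different kind of group at this position, such as an amine, a carboxylic acid or a longer alkyl chain, would give a step beyond the scatter. Also open, as far as these compounds go, is whether a change elsewhere, such as to the methyl ester of the shared core, would do so.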